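A third methoxy on the pendant phenyl ring

The source may report more compounds than this note shows. Statements on the series, on what has been measured and on what is new or still open speak of the compounds shown alone.

Measured so far:
compound 1, `Cc1cc(O)c(C2=NN(c3ccc(S(N)(=O)=O)cc3)C(c3ccccc3Cl)C2)cc1Cl`: 1890 nM
compound 2, `COc1ccc(C2CC(c3cc(Cl)c(C)cc3O)=NN2c2ccc(S(N)(=O)=O)cc2)cc1OC`: 2950 nM

In a functional assay on NCI-H522 cells (Homo sapiens) for antiproliferative activity, with a stated time of 48 h (on this read-out lower numbers stand for stronger inhibition of growth and higher numbers for weaker inhibition of growth), compound 1 gives 1890 nM and compound 2 gives 2950 nM. Compound 2 holds the highest of the two numbers, but its gap to compound 1, a 1.6-fold higher number from compound 1 to compound 2 (0.19 log units; within the scatter), lies within the scatter, so the two cannot be ordered. Compound 3, `COc1ccc(C2CC(c3cc(Cl)c(C)cc3O)=NN2c2ccc(S(N)(=O)=O)cc2)c(OC)c1OC`, is not yet measured. It differs from compound 2 by methoxy in place of hydrogen on an aromatic carbon. Among the measured compounds shown here, no measured step adds a methoxy group; the only step available, a 1.6-fold higher number from compound 1 to compound 2 (0.19 log units; within the scatter), swaps the whole pendant ring and stays within the scatter, which suggests that changes on this ring move the read-out little. On that basis no step beyond the scatter is expected in this assay, in either direction. Compound 3 is therefore estimated at 3000 nM, with a range from 1400 nM to 6500 nM, an expected step of a 1.0-fold higher number from compound 2 to compound 3 (0.01 log units; within the scatter).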

Compound 3, concentration for 50% growth inhibition: 2450 nM
Beside the measured number, compound 3's estimate is 1.2-fold (0.09 log units) above it; the range from low to high includes it.
By their numbers in this assay, from the lowest: compounds 1, 3 and 2 (each within the scatter of the next).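

In this assay, the methoxy that turns 3,4-dimethoxyphenyl into 2,3,4-trimethoxyphenyl gives a 1.2-fold lower number from compound 2 to compound 3 (0.08 log units; within the scatter) and so shows that this aromatic carbon, ortho to a large group and ortho to a methoxy group, accepts the added methoxy with no step beyond the scatter. The earlier compounds shown here had only exchanged one whole pendant ring for another, whereas this pair isolates a single added group. The comparison with the chlorinated ring gives a 1.3-fold higher number from compound 1 to compound 3 (0.11 log units; within the scatter) and leaves compound 1, compound 2 and compound 3 unordered, and no supporting data bear on why the read-out stays so flat.

The compounds shown do not tell whether an amine or a carboxylic acid on this same carbon would also stay within the scatter of compound 2 in this assay. They also leave open whether any pendant ring can move this read-out beyond the scatter.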